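The source may hold more compounds than are shown below. What is called first, only, known or untested is meant among the compounds shown, and "the series" means these compounds.

The study measures three compounds in an ADME assay on L929 cells (Mus musculus) for cytotoxicity, read by resazurin assay, with a stated time of 72 h (a lower number here means a stronger inhibitor, a higher number a weaker inhibitor), all built on a shared core. Within the data shown here, compound 1 `OB1OCc2ccc(-n3cccc3Sc3ccccc3Cl)cc21` is the first of them. In this assay compound 1 gives > 10 ug/mL, which is a limit of the assay rather than a number. Compound 2 `CCCNC(=O)c1cccn1-c1ccc2c(c1)B(O)OC2` is the second. In this assay compound 2 likewise reaches only the limit > 10 ug/mL. Compound 3 `Cc1ccc(C(=O)c2ccn(-c3ccc4c(c3)B(O)OC4)c2)cc1` is the third. In this assay compound 3 also stops at the limit > 10 ug/mL. Compound 3 therefore stands exactly where the other two stand: the limit of > 10 ug/mL in this assay, at which 3 of the 3 values shown sit. Among the measured compounds shown here, none of the three shows a number that can be ranked against another, and no step between measured compounds can be computed.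

Compound 4 `Cc1ccc(C(=O)c2ccn(-c3ccc4c(c3)B(O)OC4)c2)s1` has not yet been measured. It differs from compound 3 in one place: 5-methylthiophen-2-yl in place of 4-methylphenyl on a carbonyl carbon. The 5-methylthiophen-2-yl group simply takes the seat of the 4-methylphenyl group on the carbonyl carbon, the rest of the molecule untouched.

With every measured value sitting at the limit, the account expects no step beyond the scatter in this assay; the estimated step that the limit leaves unreadable from compound 3 to compound 4 expresses that. Compound 4 is expected to give about 30 ug/mL in this assay, within a range from 10 ug/mL to 100 ug/mL, and most likely to be reported again only as a limit.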

Compound 4, half-maximal inhibitory concentration: > 10 ug/mL
Compound 4: a limit, no number; the forecaster's own chance of this, stated with the estimate: 80%; the middle value lies beyond the limit too.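

Among these compounds, no step from compound 3 to compound 4 can be read, because each value is a limit of the assay and not a number: the limit of > 10 ug/mL in this assay, at which 4 of the 4 values shown sit. The compounds shown leave open what numbers they would give in this assay, and whether 5-methylthiophen-2-yl in place of 4-methylphenyl on a carbonyl carbon changes the read-out at all.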